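Replacing 2-phenylethenyl with thiophen-3-yl: from compound 1 to compound 3

The source may report more compounds than this note shows. Statements on the series, on what has been measured and on what is new or still open speak of the compounds shown alone.

Measured in an ADME assay on NIH3T3 cells (Mus musculus) for inhibition, read by MTT assay, with a stated time of 48 h; a lower number here means a stronger inhibitor, a higher number a weaker inhibitor:
- compound 1 `C(=C/c1nc2ccccn2c1Sc1ccccc1)\c1ccccc1`: > 100000 nM (a limit of the assay, not a number)
- compound 2 `CS(=O)(=O)c1ccc(-c2nc3ccccn3c2Sc2cccc3ccccc23)cc1`: 86400 nM

Compound 1 stands at the limit of > 100000 nM in this assay, at which 1 of the 2 values shown sits, which gives a limit and no number. Compound 3 `c1ccc(Sc2c(-c3ccsc3)nc3ccccn23)cc1` carries thiophen-3-yl in place of 2-phenylethenyl on an aromatic carbon. Among the measured compounds shown here, no measured compound pair differs in one place only, so the series offers no direct precedent for this change. In this assay, the expected step is no larger than the scatter, and no firm direction is expected. For the measured compounds named here, the only numerical guide is compound 2 at 86400 nM, so weak inhibition is also expected for compound 3. The estimate for compound 3 is 90000 nM. The expected range for compound 3 runs from 35000 nM to 200000 nM. The estimated change is an at least 1.1-fold lower number from compound 1 to compound 3 (0.04 log units; that floor lies within the scatter). A reading that gives only a limit is also expected to be about as likely as a number.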

Compound 3, half-maximal inhibitory concentration: 94100 nM
The estimate for compound 3 lay 1.0-fold (0.02 log units) below the measured number; the range from low to high includes it.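

In this assay, the exchange of 2-phenylethenyl for thiophen-3-yl gives the series its first comparison at a single place, an at least 1.0-fold lower number from compound 1 to compound 3 (0.02 log units; that floor lies within the scatter), and this floor fixes no direction for the change. Compound 3 gives 94100 nM, so this position on the aromatic carbon can carry thiophen-3-yl and still yield a number in this assay, although that number reflects only weak inhibition. The true size of the step remains unknown, because compound 1 gives a limit of the assay and not a number: the limit of > 100000 nM in this assay, at which 1 of the 3 values shown sits.

The compounds shown leave open whether an amine, a carboxylic acid or a longer alkyl chain at this position would give a clearly lower number than thiophen-3-yl does. The phenylsulfanyl group is the same in compound 1 and compound 3, and no pair shown varies it alone, so its contribution to the values remains undefined.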